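Allyl to propargyl on the amide of compound 2

The source may hold more compounds than are shown below. What is called first, only, known or untested is meant among the compounds shown, and "the series" means these compounds.

Two compounds stand measured in a functional assay on BV-2 cells (Mus musculus) for inhibition, read by Griess assay, with a stated time of 24 h; a lower number here means a stronger inhibitor, a higher number a weaker inhibitor:
compound 1 `Cc1cc(Cl)ccc1OC(=O)[C@@H]1CCC(=O)N1`: 19400 nM
compound 2 `C=CCNC(=O)[C@@H]1CCC(=O)N1`: 9100 nM

Compound 2 holds the lower of the two numbers; compound 1 sits beyond the scatter above it. Compound 3 `C#CCNC(=O)[C@@H]1CCC(=O)N1` differs from compound 2 by ethynyl in place of vinyl on a saturated chain carbon bound to an amide-type nitrogen. Going by the values given here, no step between measured compounds is available, so this change has no measured precedent. For ethynyl in place of vinyl on a saturated chain carbon bound to an amide-type nitrogen, a step of a 1.1-fold lower number from compound 2 to compound 3 (0.06 log units; within the scatter) within the scatter is expected, in no firm direction. Compound 3 is estimated at 8000 nM, with a range from 3000 nM to 20000 nM.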

Compound 3, half-maximal inhibitory concentration: 6000 nM
Beside the measured number, compound 3's estimate is 1.3-fold (0.12 log units) above it, within the range that was stated.
By their numbers in this assay, from the lowest: compounds 3 and 2 (each within the scatter of the next); then compound 1.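

In this assay, going by these compounds alone, ethynyl in place of vinyl on a saturated chain carbon bound to an amide-type nitrogen gives a 1.5-fold lower number from compound 2 to compound 3 (0.18 log units; within the scatter), the only step so far at this place. Within the data shown here, the triple bond and the double bond therefore read alike here, a point the earlier compounds could not show. No data accompany this step that would bear on its cause.

As far as these compounds go, whether a longer chain or a saturated propyl group at this place would read apart from these two remains open. From the compounds shown here alone, the effect of an amine or a carboxylic acid on the chain is equally open.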